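Compound 4 beside three analogues sitting at the limit

A few compounds are considered here, and "the series" means these few. Any claim that something is new, unique, unknown or untested is made for them only; others in the source may bear on it.

Measured so far:
compound 1 `FC(F)(F)c1ccc(CSc2nc(Nc3ccccc3Cl)c3ccccc3n2)cc1`; in a functional assay on HGC-27 cells (Homo sapiens) for cytotoxicity, read by MTT assay, with a stated time of 72 h (a higher number here means a weaker inhibitor, a lower number a stronger inhibitor), compound 1 gives > 50000 nM, a limit of the assay rather than a number.
compound 2 `COc1ccccc1Nc1nc(SCc2ccc(C(F)(F)F)cc2)nc2ccccc12`; in this assay compound 2 gives > 50000 nM, again a limit.
compound 3 `O=[N+]([O-])c1cccc(Nc2nc(SCc3ccc(C(F)(F)F)cc3)nc3ccccc23)c1`; in this assay compound 3 gives > 50000 nM, also a limit.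

Compound 3 thus stands at the limit of this assay, where every value shown sits (the limit of > 50000 nM in this assay, at which 3 of the 3 values shown sit). The steps a step that the two limits leave unreadable from compound 1 to compound 2, a step that the two limits leave unreadable from compound 1 to compound 3 and a step that the two limits leave unreadable from compound 2 to compound 3 are all of unreadable size for that reason. Compound 4 `FC(F)(F)c1ccc(CSc2nc(Nc3ccc(Cl)cc3)c3ccccc3n2)cc1` differs from compound 3 by 4-chlorophenyl in place of 3-nitrophenyl on a nitrogen on an aromatic ring. The measured steps bear on this change only as limits and give no readable size in this assay. Compound 4 is therefore expected to stay at the limit, with a number no higher from compound 3 to compound 4 (the limit leaves the size open) meaning no readable step. The estimate for compound 4 in this assay is 50000 nM, with a range from 20000 nM to 200000 nM.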

Compound 4, half-maximal inhibitory concentration: 14100 nM
For compound 4 the middle estimate is 3.5-fold (0.55 log units) above the measured one, and the stated range ends above it.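

In this assay, the aryl group on the nitrogen can bring the read-out off the limit: the change to 4-chlorophenyl gives an at least 3.5-fold lower number from compound 3 to compound 4 (0.54 log units; beyond the scatter) and an at least 3.5-fold lower number from compound 2 to compound 4 (0.54 log units; beyond the scatter). The 2-chlorophenyl and 4-chlorophenyl groups are not interchangeable here: an at least 3.5-fold lower number from compound 1 to compound 4 (0.54 log units; beyond the scatter). The steps among compounds 1, 2 and 3 cannot be read: the limit of > 50000 nM in this assay, at which 3 of the 4 values shown sit.

As far as these compounds go, the full size of the three new steps stays open, with each one measured from a limit. Also open, from the compounds shown here alone, is whether a 4-aminophenyl or 4-carboxyphenyl group on the same nitrogen would keep the number off the limit.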